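This account rests on a few compounds, and the source may have more. Where it says the series, first, only, none or still open, it means among the compounds named here.

Measured compounds:
- compound 2 `Oc1ccccc1-c1cc(-c2ccccc2C(F)(F)F)cc(-c2ccccc2O)n1` gives 22500 nM
- compound 1 `Oc1ccc(-c2cc(-c3ccc(F)cc3)cc(-c3ccccc3O)n2)cc1` gives > 50000 nM, a limit of the assay
- compound 3 `Oc1ccccc1-c1cc(-c2ccc(C(F)(F)F)cc2)cc(-c2ccccc2O)n1` gives > 50000 nM, a limit of the assay

In a functional assay on T47D cells (Homo sapiens) for inhibition (on this read-out lower numbers stand for stronger inhibition and higher numbers for weaker inhibition), compound 2 holds the only number shown; the other two values sit at the limit of > 50000 nM in this assay, at which 2 of the 3 values shown sit. The step from compound 2 to compound 3 gave an at least 2.2-fold higher number from compound 2 to compound 3 (0.34 log units; beyond the scatter). Compound 4 `Oc1ccc(-c2cc(-c3ccccc3C(F)(F)F)cc(-c3ccccc3O)n2)cc1` differs from compound 2 by 4-hydroxyphenyl in place of 2-hydroxyphenyl on an aromatic carbon. Among the compounds with values here, no measured step covers this change directly. Compound 1, which carries the 4-hydroxyphenyl group, gives > 50000 nM, a limit of the assay. A weakening is therefore expected from compound 2 to compound 4: a 2.0-fold higher number from compound 2 to compound 4 (0.30 log units; within the scatter). Compound 4 is estimated at 45000 nM, with a range from 15000 nM to 120000 nM, and a limit rather than a number is the likelier read-out.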

Compound 4, half-maximal inhibitory concentration: 7180 nM
Beside the measured number, compound 4's estimate is 6.3-fold (0.80 log units) above it; the measured number lies below the stated range.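

In this assay, 4-hydroxyphenyl in place of 2-hydroxyphenyl next to the ring nitrogen gives a 3.1-fold lower number from compound 2 to compound 4 (0.50 log units; beyond the scatter), so this position accepts the change when 2-(trifluoromethyl)phenyl is the other group. With 4-hydroxyphenyl kept, 2-(trifluoromethyl)phenyl in place of 4-fluorophenyl gives an at least 6.9-fold lower number from compound 1 to compound 4 (0.84 log units; beyond the scatter), a step read against a limit of the assay. The 4-hydroxyphenyl group alone therefore does not tie a compound to the limit: the limit of > 50000 nM in this assay, at which 2 of the 4 values shown sit.

Open, as far as these compounds go, is whether the hydroxyl itself matters at this position, as a methoxy group or an amine in its place would show.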